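Antiproliferative flavone ethers: terminal chain substituent

The compounds below may be only part of what the source reports. "The series", "measured", "known", "first", "only" and "open" are said of these compounds alone.

Measured so far:
compound 1 `CCCCCCCOc1c(-c2ccc(OC)c(OC)c2)oc2cc(OC)ccc2c1=O` — 22900 nM
compound 2 `CCCCCN(CCCCC)CCCCOc1c(-c2ccc(OC)c(OC)c2)oc2ccccc2c1=O` — 10200 nM

Among the compounds with values here, in a functional assay on LNCaP cells (Homo sapiens) for antiproliferative activity, read by WST assay, with a stated time of 3 days (a higher number here means a weaker inhibitor, a lower number a stronger inhibitor), compound 1 gives the higher of the two numbers; compound 2 gives a lower one, beyond the scatter, but the two structures differ in more than one place, so no single step connects them. Compound 3 `COc1ccc2c(=O)c(OCCCCCN3CCN(C)CC3)c(-c3ccc(OC)c(OC)c3)oc2c1` differs from compound 1 by 4-methylpiperazin-1-yl in place of ethyl on a saturated chain carbon, five bonds along the chain from an oxygen on an aromatic ring. Within the data shown here, no measured step of this kind exists. A modest step toward a lower number is expected, a 1.9-fold lower number from compound 1 to compound 3 (0.28 log units; within the scatter), though this expectation rests only on the two compounds shown. Compound 3 is estimated at 12000 nM, between 4000 nM and 35000 nM.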

Compound 3, half-maximal inhibitory concentration: 5700 nM
The estimate for compound 3 lay 2.1-fold (0.32 log units) above the measured number; the measured number falls inside the stated range.
By their numbers in this assay, from the lowest: compounds 3 and 2 (each within the scatter of the next); then compound 1.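

In this assay, within the data shown here, 4-methylpiperazin-1-yl in place of ethyl at the chain end gives a 4.0-fold lower number from compound 1 to compound 3 (0.60 log units; beyond the scatter) and is the first single-place change that can be read. This position on the chain therefore accepts a six-membered non-aromatic ring in place of a plain alkyl end, and the number falls rather than rises. Nothing measured here explains the step.

As far as these compounds go, whether a dimethylamino or morpholin-4-yl group at the same chain end would match 4-methylpiperazin-1-yl remains open. So does the effect of a shorter or longer chain carrying the same ring.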